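This account rests on a few compounds, and the source may have more. Where it says the series, first, only, none or still open, it means among the compounds named here.

Measured in a physicochemical assay for lipophilicity, at pH 7.4; on this read-out lower numbers stand for lower lipophilicity and higher numbers for higher lipophilicity:
compound 1 `CCc1ccc(N(CC(C)C)S(=O)(=O)c2ccc3c(c2)C(O)CC(C2CCN(S(C)(=O)=O)CC2)O3)cc1` — compound 1 gives 3.22
compound 2 `CC(C)CN(Cc1ccccc1C(F)(F)F)S(=O)(=O)c1ccc2c(c1)C(O)CC(C1CCOCC1)O2` — compound 2 gives 4.23
compound 3 `Cc1cc(C(O)(C(F)(F)F)C(F)(F)F)ccc1N(CC(C)C)S(=O)(=O)c1ccc2c(c1)C(O)CC(C1CCOCC1)O2` — compound 3 gives 4.37

Compound 2 stands second highest of the three numbers in this assay. Its nearest neighbour is compound 3, whose number sits higher by an amount within the usual scatter, so the two cannot be placed in order. Furthest from it is compound 1, whose number sits lower by an amount beyond the scatter. Within the data shown here, no two of the measured compounds differ in a single place, so no measured step is available to lean on.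

Compound 4 `CC(C)CN(c1ccc(N(C)C)cc1)S(=O)(=O)c1ccc2c(c1)C(O)CC(C1CCOCC1)O2` has not yet been run in this assay. Against compound 2 it differs in one place: 4-(dimethylamino)phenyl in place of 2-(trifluoromethyl)benzyl on a sulfonamide nitrogen. With no measured step of this kind in the set, the expectation rests on the change itself, and the number for compound 4 is expected to move downward by a clear margin, beyond the scatter, rather than to hold level. The step from compound 2 to compound 4 is estimated at a number 1.13 log units lower from compound 2 to compound 4 (beyond the scatter). For compound 4 the estimate in this assay is 3.1, with a range from 2.6 to 3.6.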

Compound 4, distribution coefficient: 3.51
The estimate for compound 4 lay 0.41 log units below the measured number; low and high end bracket the measured number.
By their numbers in this assay, from the lowest: compounds 1 and 4 (each within the scatter of the next); then compounds 2 and 3 (each within the scatter of the next).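

In this assay, among these compounds, the change of 4-(dimethylamino)phenyl in place of 2-(trifluoromethyl)benzyl on a sulfonamide nitrogen gives a number 0.72 log units lower from compound 2 to compound 4 (beyond the scatter), the only measured single-place step so far. Among the compounds shown here, this shows that the read-out responds to the group at this position when the rest of the molecule is held constant, which the earlier compounds, differing in more than one place, could not show. The exchange removes a group of 11 heavy atoms carrying three fluorines and no hydrogen-bond acceptor and introduces one of 9 heavy atoms carrying one nitrogen and one hydrogen-bond acceptor, but nothing at hand says why the number moves.

The single step changes the fluorines, the added nitrogen and the link between the ring and the sulfonamide nitrogen all at once, so its size cannot be divided among these features. Plain phenyl and plain benzyl on the same sulfonamide nitrogen would separate those contributions, and a 4-methoxyphenyl or 4-carboxyphenyl group would show how far the step depends on the dimethylamino group itself.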